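Cyclopropyl ether at the phenol oxygen of compound 1

This account rests on a few compounds, and the source may have more. Where it says the series, first, only, none or still open, it means among the compounds named here.

Compound 1 `O=C(O)C[C@@H](NC(=O)[C@@H]1CCCN1S(=O)(=O)c1cc(Cl)cc(Cl)c1)c1ccc(O)cc1` is the reference point. In an assay on RPMI-8866 cells for inhibition of integrin alpha-4/beta-1 (Homo sapiens) (a higher number here means a weaker inhibitor, a lower number a stronger inhibitor), compound 1 gives 0.74 nM, the second highest of the three numbers in hand. Compound 2 `O=C(O)C[C@@H](NC(=O)[C@@H]1CCN1S(=O)(=O)c1cc(Cl)cc(Cl)c1)c1ccc(OC2CCCC2)cc1`, which carries a cyclopentyloxy group on a different core, gives 0.5 nM in this assay, within the scatter of compound 1. Compound 3 `O=C(O)C[C@@H](NC(=O)[C@@H]1CCN1S(=O)(=O)c1cc(Cl)cc(Cl)c1)c1ccc(Cl)c(F)c1`, with chloro and fluoro on the aromatic ring instead of an oxygen substituent, gives 11 nM, a gap to compound 1 that lies beyond the scatter.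

Compound 4 `O=C(O)C[C@@H](NC(=O)[C@@H]1CCCN1S(=O)(=O)c1cc(Cl)cc(Cl)c1)c1ccc(OC2CC2)cc1` differs from compound 1 in one place: cyclopropyl in place of hydrogen on an oxygen on an aromatic ring. Among the measured compounds shown here, no measured pair shows exactly this step, so the expectation rests on the oxygen-substituted analogues. Compound 2, with a larger ring on the same oxygen, gives 0.5 nM, so a large move in either direction is not expected. The step of a 1.2-fold lower number from compound 1 to compound 4 (0.09 log units; within the scatter) is estimated to stay within the scatter. Compound 4 is therefore expected to give about 0.6 nM in this assay, with a range from 0.25 nM to 1.5 nM.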

Compound 4, half-maximal inhibitory concentration: 0.85 nM
Estimate against measurement, compound 4: 1.4-fold (0.15 log units) below; the range from low to high includes it.
By their numbers in this assay, from the lowest: compounds 2, 1 and 4 (each within the scatter of the next); then compound 3.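

In this assay, among the compounds shown here, the step of a 1.1-fold higher number from compound 1 to compound 4 (0.06 log units; within the scatter) is the first direct reading at this position, and it lies within the scatter. On the core of compound 1, the hydrogen on this oxygen can therefore be replaced by cyclopropyl with no change beyond the scatter, though this rests on a single pair. No measurement in hand bears on the reason for this result.

Open, going by these compounds, is whether the oxygen tolerates substituents of another kind to the same degree, such as a chain ending in an amine or a carboxylic acid, or a longer chain such as n-butyl. Also open, on these data alone, is whether hydroxy to cyclopropyloxy reads the same on the core of compound 2.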